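Anilinopyrimidine ureas: alkylphenyl replacing fluoro-methoxyphenyl

This account rests on a few compounds, and the source may have more. Where it says the series, first, only, none or still open, it means among the compounds named here.

Compound 3 `COc1cc(NC(=O)Nc2cc(Nc3cc(F)ccc3OC)ncn2)cc(OC)c1` stands second highest of the three measured in a functional assay on HCC827 cells (Homo sapiens) for inhibition, read by MTT assay, with a stated time of 48 h, tested at 10 uM (on this read-out lower numbers stand for less inhibition and higher numbers for more inhibition at the one concentration tested (going by the name of the read-out)), where compound 3 gives 59%. Compound 2 `COc1cc(NC(=O)Nc2cc(Nc3ccc(C)c(F)c3)ncn2)cc(OC)c1` gives 72%, and compound 1 `COc1cc(NC(=O)Nc2cc(Nc3ccc(C(C)(C)C)cc3)ncn2)cc(OC)c1` gives 32.7%. Compound 4 `CCc1cccc(Nc2cc(NC(=O)Nc3cc(OC)cc(OC)c3)ncn2)c1` differs from compound 3 by 3-ethylphenyl in place of 5-fluoro-2-methoxyphenyl on a nitrogen on an aromatic ring. Going by the values given here, two steps bear on this: a number 26.3 percentage points higher from compound 1 to compound 3 (beyond the scatter) and a number 13 percentage points lower from compound 2 to compound 3 (beyond the scatter); the unsubstituted-ring-plus-alkyl pattern of compound 1 scored lowest, while compound 2 scored highest, so alkylphenyl groups on that nitrogen sit on both sides of compound 3. No clear direction is therefore expected for compound 4, only a step of roughly a number 9 percentage points lower from compound 3 to compound 4 (within the scatter) in this assay. Compound 4 is estimated at 50%, with a range from 25% to 75%.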

Compound 4, a percentage reported as inhibition, at one concentration (the size of the read-out at that concentration, not a potency): 52.6%
Compound 4: middle estimate off by 2.6 percentage points, on the low side, within the range that was stated.
By their numbers in this assay, from the lowest: compound 1; then compounds 4 and 3 (each within the scatter of the next); then compound 2.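

In this assay, 3-ethylphenyl on this nitrogen gives a number 6.4 percentage points lower from compound 3 to compound 4 (within the scatter), so a ring carrying only carbon in its substituent can stand in for 5-fluoro-2-methoxyphenyl in this read-out. The other two steps, a number 19.4 percentage points lower from compound 2 to compound 4 (beyond the scatter) and a number 19.9 percentage points higher from compound 1 to compound 4 (beyond the scatter), place 3-ethylphenyl clearly apart from both 3-fluoro-4-methylphenyl and 4-(tert-butyl)phenyl, so the alkyl-bearing rings on this nitrogen span a wide band. No measurement at hand accounts for these differences.

Open, on these data alone, is whether a longer chain, as in 3-propylphenyl, or an amine, as in 3-aminophenyl, would keep this level.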